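A few compounds are considered here, and "the series" means these few. Any claim that something is new, unique, unknown or untested is made for them only; others in the source may bear on it.

Measured compounds: compound 1 `ClCc1ccc(Cn2cnc3c(Cl)ncnc32)cc1` gives 49000 nM in a functional assay on NCI-H226 cells (Homo sapiens) for cytotoxicity, read by sulforhodamine B assay, with a stated time of 48 h; a lower number here means that less compound is tolerated, a higher number that more compound is tolerated; compound 2 `ClCc1ccccc1Cn1cnc2c(Cl)nc(Cl)nc21` gives 6760 nM in this assay.

Compound 2 stands at the lowest of the two numbers, and its gap to compound 1 lies beyond the scatter. Compound 3 `ClCc1ccccc1Cn1cnc2c(Cl)ncnc21` differs from compound 2 in one place: hydrogen in place of chloro on an aromatic carbon. Within the data shown here, no measured pair shows this change on its own, so the size of the step in this assay is uncertain; a moderate rise is expected, as the only other compound, compound 1, also lacks this chloro group. For compound 3 the expected value is 18000 nM, within 5000 nM to 70000 nM, a step of a 2.7-fold higher number from compound 2 to compound 3 (0.43 log units; beyond the scatter).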

Compound 3, concentration lethal to 50% of the cells: 38900 nM
Compound 3: middle estimate off by 2.2-fold (0.33 log units), on the low side; the measured number falls inside the stated range.
By their numbers in this assay, from the lowest: compound 2; then compounds 3 and 1 (each within the scatter of the next).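

Among these compounds, this is the first pair of compounds that isolates the chloro group on the aromatic carbon between two ring nitrogen atoms. In this assay, hydrogen in its place gives a 5.8-fold higher number from compound 2 to compound 3 (0.76 log units; beyond the scatter) and so more compound is tolerated without this chloro group. No measurement shown explains the size or direction of this step.

Going by these compounds, it remains open how an amine or a methoxy group at this position would compare with chloro and hydrogen. On these data alone, whether the step carries over to other cell types also remains open.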